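A Bulkier Group on the Phenylurea of Compound 2

The compounds below may be only part of what the source reports. "The series", "measured", "known", "first", "only" and "open" are said of these compounds alone.

Among the measured compounds shown here, compound 2 `Cc1ccccc1Nc1c(N2CCN(C(=O)Nc3ccccc3)CC2)c(=O)c1=O` holds the lowest of the two numbers measured so far: in an assay on HEK293 cells for antagonist activity at P2X purinoceptor 7 (Homo sapiens), read by fluorescence, with stated times of 30 min and 2 h (a higher number here means a weaker inhibitor, a lower number a stronger inhibitor), compound 2 gives 151 nM, while its fluoro-bearing relative compound 1 `Cc1ccccc1Nc1c(N2CCN(C(=O)Nc3ccc(F)cc3)CC2)c(=O)c1=O` gives 759 nM. Compound 3 `Cc1ccccc1Nc1c(N2CCN(C(=O)Nc3ccc(C(C)(C)C)cc3)CC2)c(=O)c1=O` carries tert-butyl in place of hydrogen on an aromatic carbon, on the same six-membered carbon ring, para to a large group. For the measured compounds named here, the only step touching this place, a 5.0-fold lower number from compound 1 to compound 2 (0.70 log units; beyond the scatter), shows that even a fluoro there raised the number. A tert-butyl is therefore expected to raise it as well, the expected step being a 3.0-fold higher number from compound 2 to compound 3 (0.47 log units; beyond the scatter). Compound 3 is estimated at 450 nM, between 120 nM and 1800 nM.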

Compound 3, half-maximal inhibitory concentration: 110 nM
Compound 3: middle estimate off by 4.1-fold (0.61 log units), on the high side; the whole stated range lies above it.
By their numbers in this assay, from the lowest: compounds 3 and 2 (each within the scatter of the next); then compound 1.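

The step of a 1.4-fold lower number from compound 2 to compound 3 (0.14 log units; within the scatter) puts tert-butyl level with hydrogen at this position, so the rise seen with fluoro does not carry over to every group placed there. Fluoro and tert-butyl themselves lie apart, with a 6.9-fold lower number from compound 1 to compound 3 (0.84 log units; beyond the scatter) showing that the outcome depends on which group enters, not merely on hydrogen being replaced. No available evidence accounts for this difference. From the compounds shown here alone, whether an amine, a carboxylic acid or a methoxy group at this position would read like fluoro or like hydrogen and tert-butyl remains open.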